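Heteroaryl ether and thioether variation at the ketone methylene

This account rests on a few compounds, and the source may have more. Where it says the series, first, only, none or still open, it means among the compounds named here.

Measured compounds:
Compound 1 `CC(C)[C@H](NC(=O)COc1cccc2ccccc12)C(=O)N[C@@H](CC(=O)O)C(=O)CSC1=NCCS1` gives in a functional assay on Jurkat cells (Homo sapiens) for inhibition (a higher number here means a weaker inhibitor, a lower number a stronger inhibitor), only a limit, > 200000 nM.
Compound 2 `CC(C)[C@H](NC(=O)COc1cccc2ccccc12)C(=O)N[C@@H](CC(=O)O)C(=O)COc1ccncn1` gives in this assay only a limit, > 200000 nM.
Compound 3 `Cc1cc(C)nc(SCC(=O)[C@H](CC(=O)O)NC(=O)[C@@H](NC(=O)COc2cccc3ccccc23)C(C)C)n1` gives in this assay only a limit, > 200000 nM.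

Compound 3 stands where every measured member of the series stands: at the limit of this assay, with no number beneath it, as the limit of > 200000 nM in this assay, at which 3 of the 3 values shown sit, records. The steps among the three measured compounds, a step that the two limits leave unreadable from compound 1 to compound 2, a step that the two limits leave unreadable from compound 1 to compound 3 and a step that the two limits leave unreadable from compound 2 to compound 3, are each unreadable for this reason; none of them shows whether the change at the saturated chain carbon bound to a carbonyl carbon moves potency at all.

Compound 4 `CC(C)[C@H](NC(=O)COc1cccc2ccccc12)C(=O)N[C@@H](CC(=O)O)C(=O)COc1ccc2ccccc2n1` differs from compound 3 by (quinolin-2-yl)oxy in place of (4,6-dimethylpyrimidin-2-yl)sulfanyl on a saturated chain carbon bound to a carbonyl carbon. The two steps that touch the same place, from compound 1 to compound 3 and from compound 2 to compound 3, bear on it, but both are hidden by the limit, so no direction and no size can be taken from them. Compound 4 is therefore expected to sit near the limit again, with a small chance of a readable number; the expected step is a number no higher from compound 3 to compound 4 (the limit leaves the size open). Compound 4 is estimated at 200000 nM, with a range from 40000 nM to 500000 nM.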

Compound 4, half-maximal inhibitory concentration: > 200000 nM
Compound 4 was reported as a limit (the forecaster's own chance of this, stated with the estimate: 70%); the middle value lies on the limit itself.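

Compound 4 is a limit in this assay, like compound 1, compound 2 and compound 3, so none of the steps to compound 4 can be read: the limit of > 200000 nM in this assay, at which 4 of the 4 values shown sit. The compounds shown leave open whether any of these groups, on the saturated chain carbon bound to a carbonyl carbon, moves potency at all.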